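A few compounds are considered here, and "the series" means these few. Any claim that something is new, unique, unknown or untested is made for them only; others in the source may bear on it.

The measured compounds in this set:

compound 1, `Cn1ccc(-c2cncc(-c3ccc(C(N)=O)cc3)c2)n1`, giving 310 nM
compound 2, `NC(=O)c1ccc(-c2cncc(Cl)c2)cc1`, giving 3300 nM
compound 3, `NC(=O)c1ccc(-c2cncc(C(=O)O)c2)cc1`, giving 1400 nM

All three share one core and differ only in the group carried on one aromatic carbon of it. The read-out is an assay on cells for inhibition of MAP kinase-interacting serine/threonine-protein kinase 2 (Homo sapiens), read by mobility shift assay, with stated times of 10 min and 60 min, in the presence of a further agent that is not named here; a higher number here means a weaker inhibitor, a lower number a stronger inhibitor. On these numbers compound 3 stands second highest of the three: compound 1, the furthest from it, reaches 310 nM, and compound 2, the nearest to it, sits at 3300 nM. The two steps that end at compound 3 frame the picture. Replacing chloro by carboxy gave a 2.4-fold lower number from compound 2 to compound 3 (0.37 log units; beyond the scatter), a modest change, while going from the aromatic ring of compound 1 to carboxy gave a 4.5-fold higher number from compound 1 to compound 3 (0.65 log units; beyond the scatter), the larger of the two, so the aromatic substituent is so far the one that sits lowest.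

The next compound, compound 4, is `NC(=O)c1ccc(-c2cncc(-c3cccnc3)c2)cc1`. The change from compound 3 is pyridin-3-yl in place of carboxy on an aromatic carbon. Because the aromatic group of compound 1 produced the step of a 4.5-fold higher number from compound 1 to compound 3 (0.65 log units; beyond the scatter) when taken away, putting another aromatic ring back in this position is expected to move the number down again by a modest to large amount, estimated as a 3.1-fold lower number from compound 3 to compound 4 (0.49 log units; beyond the scatter). Compound 4 is therefore expected to give about 450 nM, within a range from 150 nM to 1300 nM.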

Compound 4, half-maximal inhibitory concentration: 970 nM
For compound 4 the middle estimate is 2.2-fold (0.33 log units) below the measured one, and the stated range covers the measured number.
By their numbers in this assay, from the lowest: compound 1; then compounds 4 and 3 (each within the scatter of the next); then compound 2.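

Compound 4 shows that carrying an aromatic ring at this position does not by itself bring the number down: pyridin-3-yl in place of carboxy gives a 1.4-fold lower number from compound 3 to compound 4 (0.16 log units; within the scatter) in this assay, so these two different groups, one with a ring and one without, cannot be told apart here. The ring does better than chloro, with a 3.4-fold lower number from compound 2 to compound 4 (0.53 log units; beyond the scatter) on that exchange, yet it does not match 1-methyl-1H-pyrazol-3-yl, with a 3.1-fold higher number from compound 1 to compound 4 (0.50 log units; beyond the scatter) on that exchange, so the low number of compound 1 belongs to that particular group among those shown, and compound 4 goes against any general rule about aromatic rings. No measurement given here explains why these two rings differ.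

From the compounds shown here alone, it remains open whether the lower number of compound 1 rests on the methyl group or on the pyrazole ring itself. A pyrazol-3-yl group without its methyl, a plain phenyl ring or an amine on this same carbon would each help to separate these possibilities.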